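A few compounds are considered here, and "the series" means these few. Any claim that something is new, unique, unknown or untested is made for them only; others in the source may bear on it.

In a physicochemical assay for solubility, using the shake flask method, in phosphate buffer, measured as kinetic solubility, with a stated time of 20 h, at pH 6.5 (on this read-out higher numbers stand for higher solubility and lower numbers for lower solubility), two compounds sharing one core have been measured so far. Compound 1 `FC1(F)CCC(c2nc3cnc(Nc4ccc(C(F)(F)F)cn4)cc3[nH]2)C1` gives 120000 nM and compound 2 `FC1(F)CC(c2nc3cnc(Nc4ccc(C(F)(F)F)cn4)cc3[nH]2)C1` gives 118000 nM, so compound 2 stands level with compound 1 within the scatter of the measurement. Compound 3 `FC(F)(F)c1ccc(Nc2cc3[nH]c([C@H]4CC[C@H](C(F)(F)F)CC4)nc3cn2)nc1` is altered at the same place, on an aromatic carbon of the five-membered aromatic ring, between two ring nitrogen atoms: 4-(trifluoromethyl)cyclohexyl in place of 3,3-difluorocyclobutyl on an aromatic carbon. Among the compounds with values here, only one measured step bears on this, the change of ring at that carbon, a 1.0-fold lower number from compound 1 to compound 2 (0.01 log units; within the scatter), and it lies within the scatter. Within the data shown here, that step covers only two difluorinated rings, so it offers a weak guide to 4-(trifluoromethyl)cyclohexyl, and the direction expected here is a judgement resting on the larger size of the incoming group. The expected step is a 3.0-fold lower number from compound 2 to compound 3 (0.47 log units; beyond the scatter), a modest fall beyond the scatter. Compound 3 is therefore estimated at 40000 nM, with an expected range of 8000 nM to 120000 nM.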

Compound 3, solubility: < 5000 nM
Compound 3 ended at the assay's limit; the forecaster's own chance of this, stated with the estimate: 10%; middle value at least 8.0-fold (0.90 log units) from the limit.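

In this assay compound 3 stands at a limit of the assay, and that limit is < 5000 nM. Putting 4-(trifluoromethyl)cyclohexyl in place of 3,3-difluorocyclobutyl gives an at least 23-fold lower number from compound 2 to compound 3 (1.37 log units; beyond the scatter) and putting it in place of 3,3-difluorocyclopentyl gives an at least 24-fold lower number from compound 1 to compound 3 (1.38 log units; beyond the scatter), whereas the two difluorinated rings had shown only a 1.0-fold lower number from compound 1 to compound 2 (0.01 log units; within the scatter), so the group on this aromatic carbon can move the read-out far beyond the scatter. The full size of both steps cannot be read, because compound 3 gives only a limit: the limit of < 5000 nM in this assay, at which 1 of the 3 values shown sits.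

The compounds shown do not separate the six-membered ring from its trifluoromethyl group, which a plain cyclohexyl would help to do. They also leave open how the read-out would respond to an amine or a carboxylic acid on the ring at this position.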